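The source may hold more compounds than are shown below. What is called first, only, known or untested is meant among the compounds shown, and "the series" means these compounds.

Compound 1 `CCCCCCCCS(=O)(=O)Nc1ccc(/C=C/c2ccccc2)cc1C(=O)O` gives 16300 nM in an assay on mitochondria (strain BALB/c) for inhibition of glycerol-3-phosphate acyltransferase 1, mitochondrial (Mus musculus), read by scintillation counting, with a stated time of 10 min; on this read-out lower numbers stand for stronger inhibition and higher numbers for weaker inhibition. Compound 2 `CCCCCCCCS(=O)(=O)Nc1ccc(/C=C/c2ccc(OC)cc2)cc1C(=O)O` differs from it by methoxy in place of hydrogen on an aromatic carbon, and in this assay compound 2 gives 37100 nM. The step is a 2.3-fold higher number from compound 1 to compound 2 (0.36 log units; beyond the scatter). Compound 3 `CCCCCCCCS(=O)(=O)Nc1ccc(CCc2ccccc2)cc1C(=O)O` carries a different core, the difference being (phenethyl in place of 2-phenylethenyl on an aromatic carbon), and in this assay compound 3 gives 37500 nM. That step is a 2.3-fold higher number from compound 1 to compound 3 (0.36 log units; beyond the scatter). Compound 4 `CCCCCCCCS(=O)(=O)Nc1ccc(CCc2ccc(OC)cc2)cc1C(=O)O` has not yet been measured in this assay. It differs from compound 3 by methoxy in place of hydrogen on an aromatic carbon, the same change as that between the first two compounds, made at the same place. On the core of compound 3 this change is expected to produce a 2.1-fold higher number from compound 3 to compound 4 (0.33 log units; beyond the scatter). That expectation rests on the step of a 2.3-fold higher number from compound 1 to compound 2 (0.36 log units; beyond the scatter) seen with the core of compound 1. Going by the values given here, no second example of the change is available. Compound 4 is therefore estimated at 80000 nM in this assay, expected to lie between 35000 nM and 180000 nM.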

Compound 4, half-maximal inhibitory concentration: 26300 nM
Compound 4: middle estimate off by 3.0-fold (0.48 log units), on the high side; measured number below the stated range.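

In this assay methoxy in place of hydrogen gives a 1.4-fold lower number from compound 3 to compound 4 (0.15 log units; within the scatter) on the core of compound 3, so the step seen on the core of compound 1 did not carry over: the same change on two cores in this assay, a 2.3-fold higher number (0.36 log units; beyond the scatter) from compound 1 to compound 2 and a 1.4-fold lower number (0.15 log units; within the scatter) from compound 3 to compound 4, 3.2-fold (0.51 log units) apart, beyond the scatter of two such steps. Neither of the other new steps lies beyond the scatter, with a 1.4-fold lower number from compound 2 to compound 4 (0.15 log units; within the scatter) and a 1.6-fold higher number from compound 1 to compound 4 (0.21 log units; within the scatter) as the readings. This rests on a single pair for each core, so it shows that the step on one core failed to predict the other here, but not why the two differ or how the change behaves on any further core.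

The compounds shown leave open whether another group in place of that hydrogen, such as hydroxyl or chlorine, would differ between the two cores in the same way.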